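Oxygen substituent change: compound 3 to compound 4

The compounds below may be only part of what the source reports. "The series", "measured", "known", "first", "only" and "open" are said of these compounds alone.

In an ADME assay on a cell-free system (plasma, Homo sapiens), read by HPLC, with a stated time of 120 min, at 37 degrees C (on this read-out higher numbers stand for a more stable compound and lower numbers for a less stable compound), compound 1 (`C[C@@H]1CN(C(=O)c2nc(Nc3cc(C4CC4)[nH]n3)c3cc(Cl)ccc3n2)CCN1C(=O)OCc1ccccc1`) stands at 86.2% and compound 2 (`COC(=O)N1CCN(C(=O)c2nc(Nc3cc(C4CC4)[nH]n3)c3cc(Cl)ccc3n2)C[C@H]1C`) at 84.6% while compound 3 (`CC(OC(=O)C(C)C)OC(=O)N1CCN(C(=O)c2nc(Nc3cc(C4CC4)[nH]n3)c3cc(Cl)ccc3n2)C[C@H]1C`) is lowest of the three at 17.4% remaining. Compound 4 (`CC(C)OC(=O)N1CCN(C(=O)c2nc(Nc3cc(C4CC4)[nH]n3)c3cc(Cl)ccc3n2)C[C@H]1C`) arises from compound 3 through methyl in place of (isopropylcarbonyl)oxy on a saturated chain carbon bound to an oxygen next to a carbonyl group and a saturated chain carbon (methyl in place of (isopropylcarbonyl)oxy, which also reads 1-((isopropylcarbonyl)oxy)ethyl to isopropyl). Going from benzyl to methyl on the oxygen next to a carbonyl group gives a number 1.6 percentage points lower from compound 1 to compound 2 (within the scatter) while the large steps of a number 68.8 percentage points lower from compound 1 to compound 3 (beyond the scatter) and a number 67.2 percentage points lower from compound 2 to compound 3 (beyond the scatter) both come with 1-((isopropylcarbonyl)oxy)ethyl on that oxygen. For the measured compounds named here, no measured compound carries isopropyl there. A large upward move is expected in this assay with a number 67.6 percentage points higher from compound 3 to compound 4 (beyond the scatter) as the estimated step. For compound 4 the estimate is 85% within a range of 70% to 97% remaining.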

Compound 4, percent of the compound remaining: 78.5%
Estimate against measurement, compound 4: 6.5 percentage points above, and the stated range covers the measured number.
By their numbers in this assay, from the lowest: compound 3; then compounds 4, 2 and 1 (each within the scatter of the next).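

In this assay, methyl in place of (isopropylcarbonyl)oxy on the saturated chain carbon brings a large rise (a number 61.1 percentage points higher from compound 3 to compound 4 (beyond the scatter)), so among these compounds the low number goes with that group and not with the carbon carrying it. Isopropyl on the oxygen next to a carbonyl group stays within the scatter of methyl (a number 6.1 percentage points lower from compound 2 to compound 4 (within the scatter)) and of benzyl (a number 7.7 percentage points lower from compound 1 to compound 4 (within the scatter)). Nothing at hand bears on what lies behind the large step. Open, going by these compounds, is how an amine, a carboxylic acid or a longer chain on that saturated chain carbon would read in this assay.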